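This account rests on a few compounds, and the source may have more. Where it says the series, first, only, none or still open, it means among the compounds named here.

Compound 1 `CCN(CC)C(=O)CN(c1ccc(C)cc1)S(=O)(=O)c1ccc(OC)c(OC)c1` gives in a functional assay on CHO cells for inhibition of Orexin/Hypocretin receptor type 1 (Homo sapiens), read by FLIPR and calcium flux (on this read-out higher numbers stand for weaker inhibition and lower numbers for stronger inhibition), only the limit > 10000 nM, not a number.
Compound 2 `CCN(CC)C(=O)CN(c1cccc(N(C)C)c1C#N)S(=O)(=O)c1ccc(OC)c(OC)c1` likewise gives only the limit > 10000 nM.
Compound 3 `CCN(CC)C(=O)CN(c1cc(N(C)C)ccc1C#N)S(=O)(=O)c1ccc(OC)c(OC)c1` gives 166 nM.

Within the data shown here, compound 3 thus holds the only actual number in this assay; the other two values sit at the limit of > 10000 nM in this assay, at which 2 of the 3 values shown sit. Going from compound 1 and from compound 2 to compound 3 the number fell sharply: an at least 60-fold lower number from compound 1 to compound 3 (1.77 log units; beyond the scatter) and an at least 60-fold lower number from compound 2 to compound 3 (1.77 log units; beyond the scatter), both beyond the usual scatter, while a step that the two limits leave unreadable from compound 1 to compound 2. Compound 4 `CCN(CC)C(=O)CN(c1cc(N(C)C)ccc1OC)S(=O)(=O)c1ccc(OC)c(OC)c1` differs from compound 3 in one place: methoxy in place of cyano on an aromatic carbon. Among the measured compounds shown here, no measured step swaps the cyano for another group while keeping the rest of compound 3, so the two large steps into compound 3 show only that this ring pattern, with the cyano in place, carries the activity; they do not say how much of it rests on the cyano itself. The step from compound 3 to compound 4 is therefore expected to raise the number in this assay, most likely beyond the scatter, a 9.0-fold higher number from compound 3 to compound 4 (0.96 log units; beyond the scatter). Compound 4 is estimated at 1500 nM, within 300 nM to 8000 nM.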

Compound 4, half-maximal inhibitory concentration: > 10000 nM
Compound 4 was reported as a limit; the forecaster's own chance of this, stated with the estimate: 25%; middle value at least 6.6-fold (0.82 log units) away from the limit.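

In this assay, replacing the cyano with methoxy, on the aromatic carbon para to a dimethylamino group, gives an at least 60-fold higher number from compound 3 to compound 4 (1.77 log units; beyond the scatter). Among these compounds, this step changes only that one group, so it shows that in compound 3 the activity depends on the cyano and not on the ring pattern alone, even though cyano and methoxy match in heavy atoms and hydrogen-bond acceptors as counted. Compound 4 gives only a limit, and the steps to it from compound 1 and compound 2 cannot be read: the limit of > 10000 nM in this assay, at which 3 of the 4 values shown sit.

On these data alone, whether a chlorine, an amide or a carboxylic acid at this place would keep any activity stays open. Also open is how much of the activity of compound 3 depends on the dimethylamino group, since no step shown replaces it with, for example, a methylamino group or a pyrrolidine.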